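Benzyl variation on the shared core in the receptor binding assay

The source may hold more compounds than are shown below. What is called first, only, known or untested is meant among the compounds shown, and "the series" means these compounds.

Measured compounds:
compound 1 `CC1(C)c2[nH]nc(NC(=O)c3ccccc3)c2CN1Cc1cccc(C#N)c1` gives 980 nM
compound 2 `CC1(C)c2[nH]nc(NC(=O)c3ccccc3)c2CN1Cc1cccc(I)c1` gives 1360 nM
compound 3 `CC1(C)c2[nH]nc(NC(=O)c3ccccc3)c2CN1Cc1cc(F)cc(F)c1` gives 190 nM

All values come from a binding assay on Sf21 cells for inhibition of high affinity nerve growth factor receptor (Homo sapiens), read by HTRF, with a stated time of 30 min, in the presence of a further agent that is not named here; a higher number here means a weaker inhibitor, a lower number a stronger inhibitor. Compound 2 gives the highest number of the three; its gap to compound 1 is within the scatter, while compound 3 lies clearly below it, the step from compound 2 to compound 3 being a 7.2-fold lower number from compound 2 to compound 3 (0.85 log units; beyond the scatter).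

The unmeasured compound 4 `CC1(C)c2[nH]nc(NC(=O)c3ccccc3)c2CN1Cc1cccc(F)c1F` differs from compound 2 in one place: 2,3-difluorophenyl in place of 3-iodophenyl on a saturated chain carbon bound to an amine nitrogen in a ring. The change replaces the 3-iodophenyl group with a difluorophenyl group, as the step to compound 3 did, but with a different fluorine pattern on the ring.

Going by the values given here, two measured steps bear on this. The step from compound 2 to compound 3 is a 7.2-fold lower number from compound 2 to compound 3 (0.85 log units; beyond the scatter), and the step from compound 1 to compound 3 is a 5.2-fold lower number from compound 1 to compound 3 (0.71 log units; beyond the scatter); both move from a singly substituted phenyl to the 3,5-difluorophenyl and both lower the number beyond the scatter. The step from compound 1 to compound 2 is a 1.4-fold higher number from compound 1 to compound 2 (0.14 log units; within the scatter), within the scatter. Among the compounds with values here, no measured step tells how 2,3-difluorophenyl compares with 3,5-difluorophenyl, so the direction is taken from the two difluoro steps while the size is set more cautiously. A lower number is expected, with the step from compound 2 to compound 4 estimated at a 3.0-fold lower number from compound 2 to compound 4 (0.48 log units; beyond the scatter). Compound 4 is therefore expected to give about 450 nM, with a range of 160 nM to 1200 nM.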

Compound 4, half-maximal inhibitory concentration: 200 nM
Beside the measured number, compound 4's estimate is 2.3-fold (0.35 log units) above it, and the stated range covers the measured number.
By their numbers in this assay, from the lowest: compounds 3 and 4 (each within the scatter of the next); then compounds 1 and 2 (each within the scatter of the next).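

In this assay, the change to 2,3-difluorophenyl gives a 6.8-fold lower number from compound 2 to compound 4 (0.83 log units; beyond the scatter), and the comparison with the nitrile-bearing ring gives a 4.9-fold lower number from compound 1 to compound 4 (0.69 log units; beyond the scatter), so the drop seen with 3,5-difluorophenyl is no longer tied to a single fluorine pattern at this place on the saturated chain carbon bound to the ring amine nitrogen. The direct comparison of the two difluorophenyl groups gives a 1.1-fold higher number from compound 3 to compound 4 (0.02 log units; within the scatter), so moving the fluorines between these two patterns has no readable effect in this set, and both difluorophenyl compounds stand apart from the 3-iodophenyl and 3-cyanophenyl compounds, with no compound shown going against this split. Nothing available accounts for the split between the difluorophenyl and singly substituted rings.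

Open is whether both fluorines are needed, as the compounds shown do not include a 3-fluorophenyl or an unsubstituted phenyl group on the same core. Also open, going by these compounds, is how far the pattern extends to other substituents at this place, such as a methoxy group, an aminomethyl group or a carboxylic acid on the ring.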